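Trading a Methoxy-Bearing Ring for a Fluorine-Bearing Ring

A few compounds are considered here, and "the series" means these few. Any claim that something is new, unique, unknown or untested is made for them only; others in the source may bear on it.

Among the compounds with values here, compound 2 `COc1cccc(/C=C/C(=O)Nc2cc(C(=O)c3cc(OC)c(OC)c(OC)c3)cc(OC)c2OC)c1` stands at the higher end of the two numbers measured so far: in a functional assay on PC-3 cells (Homo sapiens) for cytotoxicity, read by MTT assay, with a stated time of 72 h (on this read-out higher numbers stand for weaker inhibition and lower numbers for stronger inhibition), compound 2 gives 13300 nM, while compound 1 `COc1ccc(/C=C/C(=O)Nc2cc(C(=O)c3cc(OC)c(OC)c(OC)c3)cc(OC)c2OC)cc1OC` gives 5400 nM. Within the data shown here, the single measured step, a 2.5-fold higher number from compound 1 to compound 2 (0.39 log units; beyond the scatter), shows that putting hydrogen in place of methoxy on an aromatic carbon weakened the inhibition modestly. Compound 3 `COc1cc(C(=O)c2cc(OC)c(OC)c(OC)c2)cc(NC(=O)/C=C/c2ccc(F)cc2)c1OC` differs from compound 2 by 4-fluorophenyl in place of 3-methoxyphenyl on a double-bonded chain carbon bound to a double-bonded chain carbon. Among the measured compounds shown here, no measured step involves a fluorine on this ring, so the earlier step offers only a loose guide: the methoxy that is now lost was itself tied to only a modest change, and nothing measured speaks to what the fluorine does. The expected step of a 1.1-fold lower number from compound 2 to compound 3 (0.04 log units; within the scatter) is therefore small, in no firm direction. Compound 3 is estimated at 12000 nM in this assay, with a range from 4500 nM to 32000 nM.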

Compound 3, half-maximal inhibitory concentration: 4100 nM
Compound 3: middle estimate off by 2.9-fold (0.47 log units), on the high side; measured number below the stated range.
By their numbers in this assay, from the lowest: compounds 3 and 1 (each within the scatter of the next); then compound 2.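

Within the data shown here, earlier, the only step tied losing a methoxy to a weaker result, but on a double-bonded chain carbon bound to a double-bonded chain carbon, a ring with no methoxy can still do well. In this assay, 4-fluorophenyl in place of 3-methoxyphenyl gives a 3.2-fold lower number from compound 2 to compound 3 (0.51 log units; beyond the scatter) and thus reverses the drop seen on the way to compound 2. Set against 3,4-dimethoxyphenyl, the same ring gives a 1.3-fold lower number from compound 1 to compound 3 (0.12 log units; within the scatter) and leaves compound 1 and compound 3 indistinguishable, though no measurement here offers an explanation for either step.

From the compounds shown here alone, this swap changes both the group on the ring and where it sits, so the share of each remains open. A plain phenyl ring, or a phenyl ring bearing a chlorine, a nitrile or an amine, could help separate the two.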